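Notes on the step from compound 2 to compound 3

This account rests on a few compounds, and the source may have more. Where it says the series, first, only, none or still open, it means among the compounds named here.

- compound 1 `N#Cc1c(Nc2ccccn2)nc(SCc2nc3ccccc3[nH]2)nc1-c1ccccc1`: 3.8 nM
- compound 2 `N#Cc1c(NNC(N)=S)nc(SCc2nc3ccccc3[nH]2)nc1-c1ccccc1`: 3.2 nM

In a functional assay on RKOp27 cells (Homo sapiens) for cytotoxicity, read by MTT assay, with a stated time of 3 days (a lower number here means a stronger inhibitor, a higher number a weaker inhibitor), compound 2 stands within the scatter of compound 1, so these two numbers give no order. Compound 3 `CN1CCN(c2nc(SCc3nc4ccccc4[nH]3)nc(-c3ccccc3)c2C#N)CC1` keeps the shared core and changes one substituent: a group of 7 heavy atoms (5 carbon, 2 nitrogen; one six-membered non-aromatic ring with 2 hetero atoms) in place of a group of 5 heavy atoms (1 carbon, 3 nitrogen, 1 sulfur; no ring), on an aromatic carbon. The entering group is 4-methylpiperazin-1-yl, ortho to a cyano group.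

Among the compounds with values here, one measured step bears on this change: a 1.2-fold lower number from compound 1 to compound 2 (0.07 log units; within the scatter). There, a group on a nitrogen on an aromatic ring was exchanged with no size of effect beyond the scatter. Within the data shown here, that single step is thin evidence, and no measured compound carries the entering ring. No step beyond the scatter is therefore expected, though with a wide margin. The expected step is a 1.3-fold higher number from compound 2 to compound 3 (0.10 log units; within the scatter). For compound 3 the estimated value is 4 nM, with an expected range of 1.5 nM to 15 nM.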

Compound 3, half-maximal inhibitory concentration: 5.4 nM
The estimate for compound 3 lay 1.4-fold (0.13 log units) below the measured number; low and high end bracket the measured number.
By their numbers in this assay, from the lowest: compounds 2, 1 and 3 (each within the scatter of the next).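

In this assay, 4-methylpiperazin-1-yl, with 0 hydrogen-bond donors, replaces an open-chain group with 3 hydrogen-bond donors on the aromatic carbon ortho to a cyano group, giving a 1.7-fold higher number from compound 2 to compound 3 (0.23 log units; within the scatter). Against (pyridin-2-yl)amino the result is alike, a 1.4-fold higher number from compound 1 to compound 3 (0.15 log units; within the scatter), so all three groups at this position, including one with a six-membered non-aromatic ring and no hydrogen-bond donor, lie within the scatter of each other. No measurement at hand explains why these numbers stay so close.

From the compounds shown here alone, it remains open whether any group at this aromatic carbon gives a step beyond the scatter. A simple dimethylamino group, a morpholine ring or a carboxylic acid on a short chain would test how far this tolerance extends.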